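A few compounds are considered here, and "the series" means these few. Any claim that something is new, unique, unknown or untested is made for them only; others in the source may bear on it.

In an ADME assay on HepG2 cells (Homo sapiens) for cytotoxicity, read by MTT assay, with a stated time of 72 h (a higher number here means that more compound is tolerated, a lower number that less compound is tolerated), three compounds sharing one core have been tested so far. Compound 1 `CCCCCN(CCCCC)c1nc2cc(-c3ccc(C)cc3)sc2c(=O)[nH]1` yielded no number, and its entry reads "nd(insoluble)" (no result reported). Compound 2 `CC(C)(C)Nc1nc2cc(-c3ccc(Br)cc3)sc2c(=O)[nH]1` gives 1400 nM, while compound 3 `CC(C)Nc1nc2cc(-c3ccc(Br)cc3)sc2c(=O)[nH]1` gives 13400 nM. For the measured compounds named here, compound 2 therefore holds the lower of the only two numbers, and the pair shows a 9.6-fold higher number from compound 2 to compound 3 (0.98 log units; beyond the scatter), with hydrogen in place of methyl on a saturated chain carbon.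

The next compound is compound 4 `CC(C)(C)Nc1nc2cc(-c3ccccc3)sc2c(=O)[nH]1`, which departs from compound 2 by hydrogen in place of bromo on an aromatic carbon. This puts hydrogen in place of bromo on an aromatic carbon, para to a large group. Going by the values given here, no measured step touches that place. Among the compounds with values here, the single step available lies elsewhere in the molecule, so it offers a sense of how far numbers can move in this assay but no direction for this change. With compound 2 at 1400 nM, the lower end of what has been seen, a modest move upward is expected, though with little certainty and probably short of the full measured step. The expected change is a 2.9-fold higher number from compound 2 to compound 4 (0.46 log units; beyond the scatter). For compound 4 the estimated value is 4000 nM, with an expected range from 1200 nM to 15000 nM.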

Compound 4, half-maximal cytotoxic concentration: 12500 nM
Compound 4: the middle estimate sits 3.1-fold (0.49 log units) below what was measured; the range from low to high includes it.
By their numbers in this assay, from the lowest: compound 2; then compounds 4 and 3 (each within the scatter of the next).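

In this assay, the change from 4-bromophenyl to phenyl gives an 8.9-fold higher number from compound 2 to compound 4 (0.95 log units; beyond the scatter). For the compounds shown here, this is the first measured step at this place, on an aromatic carbon para to a large group, and it shows that exchanging the bromo for hydrogen, with the rest of the molecule unchanged, is enough to move the number upward beyond the scatter. The earlier step, a 9.6-fold higher number from compound 2 to compound 3 (0.98 log units; beyond the scatter), lies elsewhere in the molecule and runs in the same direction, so each of the two single changes away from compound 2 gives a higher number, and no measurement at hand accounts for either step.

On these data alone, it remains open whether a chloro, fluoro or methoxy group at this place would give a number closer to that of the bromo or of the hydrogen compound, and compound 1, which carries a methyl there, offers no guide, since compound 1 gives "nd(insoluble)" (no result reported). Also open, as far as these compounds go, is whether the step from 4-bromophenyl to phenyl would look the same on the amine chain of compound 3.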